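Chloro for Methyl on a Benzohydrazide: Does the Gain Repeat?

This account rests on a few compounds, and the source may have more. Where it says the series, first, only, none or still open, it means among the compounds named here.

Compound 1 `Cc1ccc(C(=O)NNC(=O)c2ccc(NS(=O)(=O)c3cnc(O)nc3O)cc2)cc1` gives > 20000 nM in a functional assay on SGC-7901 cells (Homo sapiens) for antiproliferative activity, read by MTT assay, with a stated time of 24 h (a higher number here means a weaker inhibitor, a lower number a stronger inhibitor), which is a limit of the assay rather than a number.
Compound 2 `O=C(NNC(=O)c1ccccc1Cl)c1ccc(NS(=O)(=O)c2cnc(O)nc2O)cc1` gives 3240 nM in this assay.
Compound 3 `Cc1ccc(C(=O)NNC(=O)c2ccccc2NS(=O)(=O)c2cnc(O)nc2O)cc1` gives 15500 nM in this assay.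

Among the compounds with values here, the one measured change is 2-chlorophenyl in place of 4-methylphenyl on a carbonyl carbon, and it brought an at least 6.1-fold lower number from compound 1 to compound 2 (0.79 log units; beyond the scatter); the step is known only as a lower bound because compound 1 sits at the limit of > 20000 nM in this assay, at which 1 of the 3 values shown sits. Compound 3 is built from the same atoms as compound 1 joined differently, and the difference between the two cores is not broken down here. Compound 4 `O=C(NNC(=O)c1ccccc1NS(=O)(=O)c1cnc(O)nc1O)c1ccccc1Cl` differs from compound 3 by 2-chlorophenyl in place of 4-methylphenyl on a carbonyl carbon, the same change at the same place, so the earlier step is the natural guide. Within the data shown here, compound 3 is expected to fall to compound 4 by about a 3.9-fold lower number from compound 3 to compound 4 (0.59 log units; beyond the scatter), somewhat less than the measured step, since only one pair carries it. Compound 4 is therefore estimated at 4000 nM in this assay, most likely between 1200 nM and 13000 nM.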

Compound 4, half-maximal inhibitory concentration: 2410 nM
Estimate against measurement, compound 4: 1.7-fold (0.22 log units) above; the measured number falls inside the stated range.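

In this assay, putting 2-chlorophenyl in place of 4-methylphenyl on a carbonyl carbon gave a 6.4-fold lower number from compound 3 to compound 4 (0.81 log units; beyond the scatter), so the gain seen on the core of compound 1 appeared again on a second core. Compound 1 gives > 20000 nM, which is a limit of the assay and not a number, so the earlier step is known only as a lower bound and the two steps cannot be called equal or different: the same change on two cores in this assay, an at least 6.1-fold lower number (0.79 log units; beyond the scatter) from compound 1 to compound 2 and a 6.4-fold lower number (0.81 log units; beyond the scatter) from compound 3 to compound 4; the limit leaves it open whether they differ
Two pairs show that the change carried over once, not that it will carry to every core in this series, and they cannot separate what the loss of 4-methylphenyl contributes from what the arrival of 2-chlorophenyl contributes.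

The compounds shown leave open how an unsubstituted phenyl ring would compare with either group, which would help to show how much depends on the chlorine itself. On these data alone, it also remains open how an amine or a carboxylic acid on that ring would behave.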